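The compounds below may be only part of what the source reports. "The series", "measured", "known", "first", "only" and "open" are said of these compounds alone.

The study examined a small set of sulfonyl-linked carbamates and ureas in an assay on liver for inhibition of sterol O-acyltransferase 1 (Rattus norvegicus), using microsomes; on this read-out lower numbers stand for stronger inhibition and higher numbers for weaker inhibition. Compound 1, with the structure `CCC(C)N(C(=O)NS(=O)(=O)Oc1c(C(C)C)cccc1C(C)C)C(C)CC`, gives 12000 nM in this assay. Compound 2, with the structure `CC(C)c1cccc(C(C)C)c1OC(=O)NS(=O)(=O)N1CCCCC1`, has only a limit in this assay, and that limit is > 100000 nM. In this assay compound 2 therefore stands at the weak end of what the measurements can show, a point also marked by the line (the limit of > 100000 nM in this assay, at which 1 of the 2 values shown sits), where one of the two values recorded sits.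

The unmeasured partner is compound 3, with the structure `Cc1cccc(C)c1OS(=O)(=O)NC(=O)Oc1c(C(C)C)cccc1C(C)C`. It differs from compound 2 at a single place, counted as 2,6-dimethylphenoxy in place of piperidin-1-yl on a sulfonyl sulfur. Among the compounds with values here, no measured pair in the set shares this change, so its size can only be estimated. Given that compound 2 shows only the limit > 100000 nM, and that the carbon-rich aromatic oxygen substituent brings compound 3 closer in overall shape to compound 1, which gives 12000 nM, the estimated step from compound 2 to compound 3 is expected to be an at least 4.0-fold lower number from compound 2 to compound 3 (0.60 log units; beyond the scatter), toward stronger inhibition. Compound 3 is thus expected to give about 25000 nM, with a likely range from 5000 nM to 120000 nM.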

Compound 3, half-maximal inhibitory concentration: > 50000 nM
Compound 3 ended at the assay's limit; the forecaster's own chance of this, stated with the estimate: 35%; middle value at least 2.0-fold (0.30 log units) from the limit.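

In this assay compound 2 gives > 100000 nM as a limit only. Compound 3 likewise gives > 50000 nM as a limit only, so no step can be read between compound 2 and compound 3. The compounds shown leave open whether 2,6-dimethylphenoxy in place of piperidin-1-yl on a sulfonyl sulfur changes the read-out at all.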